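Dichlorophenyl Amide Approaching a Cytotoxicity Limit

This account rests on a few compounds, and the source may have more. Where it says the series, first, only, none or still open, it means among the compounds named here.

Compound 1 `CC(Sc1nnc(-c2ccncc2)s1)C(=O)Nc1ccccc1` and compound 2 `CC(Sc1nnc(-c2ccncc2)s1)C(=O)NCc1ccccc1` share one core. In an ADME assay on HepG2 cells (Homo sapiens) for cytotoxicity, with a stated time of 3 days (a lower number here means that less compound is tolerated, a higher number that more compound is tolerated), compound 1 gives > 50000 nM, which is a limit of the assay. Compound 2 gives > 50000 nM in this assay, again a limit. The step that the two limits leave unreadable from compound 1 to compound 2 cannot be read, given (the limit of > 50000 nM in this assay, at which 2 of the 2 values shown sit). Compound 3 `CC(Sc1nnc(-c2ccncc2)s1)C(=O)Nc1c(Cl)cccc1Cl` carries 2,6-dichlorophenyl in place of benzyl on an amide-type nitrogen. For the measured compounds named here, no measured step bears on this change, since both known values are limits, so the step that the limit leaves unreadable from compound 2 to compound 3 is expected to be small, with compound 3 expected to stay near the limit. Compound 3 is estimated at 60000 nM, between 20000 nM and 200000 nM.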

Compound 3, half-maximal cytotoxic concentration: > 50000 nM
Compound 3: only a limit was reported (the forecaster's own chance of this, stated with the estimate: 80%); the middle value is on the limit's open side.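

No step among compound 1, compound 2 and compound 3 can be read, because all three values are limits: the limit of > 50000 nM in this assay, at which 3 of the 3 values shown sit.

The compounds shown leave open where each one's actual value lies in this assay, and so whether these amide nitrogen groups differ at all.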